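Replacing the 4-chlorophenyl of compound 1 with 2-phenylethenyl

A few compounds are considered here, and "the series" means these few. Any claim that something is new, unique, unknown or untested is made for them only; others in the source may bear on it.

Going by the values given here, compound 1 `O=C(COc1cccc2ccccc12)N/N=C/c1ccc(Cl)cc1` is one of three compounds measured in an ADME assay on MT4 cells (Homo sapiens) for cytotoxicity, read by MTT assay, with a stated time of 4 days; a higher number here means that more compound is tolerated, a lower number that less compound is tolerated. In this assay compound 1 gives 87.6 ug/mL, the second highest of the three numbers. Its nearest neighbour is compound 2 `O=C(COc1cccc2ccccc12)N/N=C/c1ccc([N+](=O)[O-])cc1`, which in this assay gives 87.9 ug/mL; the step of a 1.0-fold higher number from compound 1 to compound 2 (0.00 log units; within the scatter) shows that this exchange left the tolerated amount unchanged. Compound 3 `C/C(=N\NC(=O)COc1cccc2ccccc12)c1ccccc1O` lies furthest away, giving 11.3 ug/mL in this assay, a lower number beyond the scatter; compound 3 differs from compound 1 in more than one place, so only its own value can be read from it.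

Compound 4 `O=C(COc1cccc2ccccc12)N/N=C/C=C/c1ccccc1` has not yet been measured. It differs from compound 1 as follows: 2-phenylethenyl in place of 4-chlorophenyl on a carbon with a double bond to nitrogen. Among the compounds with values here, no measured step bears directly on this exchange. Within the data shown here, the only measured step that alters the 4-chlorophenyl group, a 1.0-fold higher number from compound 1 to compound 2 (0.00 log units; within the scatter), did not move the number, so the step for compound 4 is expected to be about a 1.3-fold lower number from compound 1 to compound 4 (0.10 log units; within the scatter), within the scatter. The estimated value for compound 4 in this assay is 70 ug/mL, expected to fall between 25 ug/mL and 150 ug/mL.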

Compound 4, half-maximal cytotoxic concentration: 82.7 ug/mL
For compound 4 the middle estimate is 1.2-fold (0.07 log units) below the measured one, within the range that was stated.
By their numbers in this assay, from the lowest: compound 3; then compounds 4, 1 and 2 (each within the scatter of the next).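

In this assay, putting 2-phenylethenyl in place of 4-chlorophenyl on the carbon with a double bond to nitrogen gives a 1.1-fold lower number from compound 1 to compound 4 (0.02 log units; within the scatter). The earlier step altered only a group on the aromatic ring, whereas here the whole 4-chlorophenyl leaves and the group that enters adds a double bond outside the aromatic ring, yet the tolerated amount still stays within the scatter. Nothing available explains this lack of change.

Going by these compounds alone, every group at this place so far carries an aromatic ring, so it remains open whether a carboxylic acid, an amine or a plain alkyl chain there would also leave the number in place. Compound 3 differs from compound 1 in more than one place, so which of its differences matters also remains unsettled.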